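Replacing the 4-ethylpiperazin-1-yl group of compound 3

This account rests on a few compounds, and the source may have more. Where it says the series, first, only, none or still open, it means among the compounds named here.

Measured values, all in a functional assay on HepG2 cells (Homo sapiens) for cytotoxicity, read by MTT assay, with a stated time of 72 h; on this read-out lower numbers stand for stronger inhibition and higher numbers for weaker inhibition
- compound 1 `CCN1CCN(CCC(=O)Nc2ccc3[nH]c(-c4ccc(Br)cc4)nc3c2)CC1` gives 27400 nM
- compound 2 `Cn1cccc1-c1nc2cc(NC(=O)CCl)ccc2[nH]1` gives 1800 nM
- compound 3 `CCN1CCN(CCC(=O)Nc2ccc3[nH]c(-c4ccc(C)cc4)nc3c2)CC1` gives 14600 nM

Compound 3 lies within the scatter of compound 1, and both sit well above compound 2. Compound 4 `Cc1ccc(-c2nc3cc(NC(=O)CCCl)ccc3[nH]2)cc1` has chloro in place of 4-ethylpiperazin-1-yl on a saturated chain carbon, two bonds along the chain from a carbonyl carbon. Within the data shown here, the only measured step, a 1.9-fold lower number from compound 1 to compound 3 (0.27 log units; within the scatter), is a change elsewhere and says little here. Compound 2 also carries chloro on its chain and gives 1800 nM, though it differs from compound 4 in other places too. A lower number is therefore expected in this assay, with an estimated 2.9-fold lower number from compound 3 to compound 4 (0.47 log units; beyond the scatter). For compound 4 the expected value is 5000 nM, with an estimated range of 1500 nM to 18000 nM.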

Compound 4, half-maximal inhibitory concentration: > 50000 nM
Compound 4: only a limit was reported; the forecaster's own chance of this, stated with the estimate: 8%; middle value at least 10-fold (1.00 log units) from the limit.
By their numbers in this assay, from the lowest: compound 2; then compounds 3 and 1 (each within the scatter of the next). At a limit, above all of these: compound 4.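

In this assay, the saturated chain carbon two bonds along the chain from a carbonyl carbon responds to substitution: chloro in place of 4-ethylpiperazin-1-yl gives an at least 3.4-fold higher number from compound 3 to compound 4 (0.53 log units; beyond the scatter). Compound 4 gives > 50000 nM, which is a limit of the assay and not a number. This step lies beyond the scatter, whereas the earlier step on the aromatic carbon stayed within it. As far as these compounds go, how large the step really is remains open. Also open, from the compounds shown here alone, is whether a smaller amine such as dimethylamino, or a carboxylic acid, on this chain carbon would give a number nearer that of compound 3.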